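Isopropyl in Place of Thiophen-2-yl on an Amine Nitrogen

The compounds below may be only part of what the source reports. "The series", "measured", "known", "first", "only" and "open" are said of these compounds alone.

Of the compounds shown here, three have so far been measured in a functional assay on L1210 cells (Mus musculus) for antiproliferative activity; on this read-out higher numbers stand for higher potency (the scale is a negative logarithm) and lower numbers for lower potency. In this assay compound 1 `CN(/N=N/c1ccc(C(N)=O)cc1)c1cccs1` gives 2.9, compound 2 `CN(Cc1ccccc1)/N=N/c1nc[nH]c1C(N)=O` gives 3.43, and compound 3 `CN(Cc1ccccc1)/N=N/c1ccccc1` gives 3.03. Compound 1 has the lowest of the three numbers: compound 3 lies within the scatter of it, while compound 2 lies beyond the scatter above it. Compound 4 `CC(C)N(C)/N=N/c1ccc(C(N)=O)cc1` has not yet been measured in this assay. It differs from compound 1 in one place: isopropyl in place of thiophen-2-yl on an amine nitrogen. For the measured compounds named here, no pair of measured compounds differs in only one place, so no measured step guides this change. A step of no more than the usual scatter, in either direction, is expected: a number 0.10 log units higher from compound 1 to compound 4 (within the scatter). Compound 4 is therefore estimated at 3, between 2.5 and 3.5.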

Compound 4, logarithm of the reciprocal of the active concentration, log(1/C): 3.17
For compound 4 the middle estimate is 0.17 log units below the measured one; the measured number falls inside the stated range.
By their numbers in this assay, from the lowest: compounds 1, 3, 4 and 2 (each within the scatter of the next, the first and the last beyond it).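

In this assay this position now has its first measured step, a number 0.27 log units higher from compound 1 to compound 4 (within the scatter), so for this pair an open-chain isopropyl on the amine nitrogen and the thiophen-2-yl ring cannot be told apart. At this position, the aromatic ring of compound 1 can therefore be replaced without a change beyond the scatter. Nothing at hand bears on why the two groups read alike. Still open, as far as these compounds go, is whether a longer chain, or a chain carrying a carboxylic acid or an amine, on this nitrogen would give a step beyond the scatter.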